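Changing the Ester Alcohol Part on a Shared Core

This account rests on a few compounds, and the source may have more. Where it says the series, first, only, none or still open, it means among the compounds named here.

Compound 1 `C#CCCOC(=O)C1=C(C)NC(C)=C(C(=O)OC)C1c1cccc([N+](=O)[O-])c1` gives 31 nM in a functional assay on HEK293 cells for antagonist activity at Voltage-dependent L-type calcium channel subunit alpha-1C (Oryctolagus cuniculus), read by FLIPR; on this read-out lower numbers stand for stronger inhibition and higher numbers for weaker inhibition. Going by the values given here, compound 2 `COC(=O)C1=C(C)NC(C)=C(C(=O)OCc2ccc(OC)c(OC)c2)C1c1cccc([N+](=O)[O-])c1` gives 112 nM in this assay, the higher of the two numbers measured so far; the one step measured, a 3.6-fold higher number from compound 1 to compound 2 (0.56 log units; beyond the scatter), lies beyond the scatter. Compound 3 `COC(=O)C1=C(C)NC(C)=C(C(=O)OC2Cc3ccccc3C2)C1c1cccc([N+](=O)[O-])c1` differs from compound 2 by 2,3-dihydro-1H-inden-2-yl in place of 3,4-dimethoxybenzyl on an oxygen next to a carbonyl group. Because the measured step of a 3.6-fold higher number from compound 1 to compound 2 (0.56 log units; beyond the scatter) also changed the group on that oxygen and was modest, a modest step in this assay is expected here, with no clear direction. Compound 3 is therefore estimated at 70 nM, likely between 25 nM and 200 nM. That estimate means an expected 1.6-fold lower number from compound 2 to compound 3 (0.20 log units; within the scatter).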

Compound 3, half-maximal inhibitory concentration: 72 nM
Compound 3: the middle estimate sits 1.0-fold (0.01 log units) below what was measured; measured number inside the range.
By their numbers in this assay, from the lowest: compound 1; then compounds 3 and 2 (each within the scatter of the next).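

Replacing 3,4-dimethoxybenzyl with 2,3-dihydro-1H-inden-2-yl on this oxygen (a 1.6-fold lower number from compound 2 to compound 3 (0.19 log units; within the scatter)) stays within the scatter in this assay, even though the entering group has 0 hydrogen-bond acceptors where the leaving group has 2. The 2,3-dihydro-1H-inden-2-yl group still stands apart from the but-3-yn-1-yl group (a 2.3-fold higher number from compound 1 to compound 3 (0.37 log units; beyond the scatter)), so two different ring-bearing groups now give higher numbers than that chain. Nothing measured here explains these numbers.

Going by these compounds, how an amine or a carboxylic acid on the group at this oxygen would read remains open. So does the effect of a longer chain than but-3-yn-1-yl.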